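The source may hold more compounds than are shown below. What is called first, only, known or untested is meant among the compounds shown, and "the series" means these compounds.

Measured compounds, cytotoxicity:
compound 1, `C=C1C(=O)[C@]23C[C@@]1(O)CC[C@H]2c1ccc(O)c(C)c1[C@@H]3Cn1cc(-c2ccc(C)cc2)nn1`: 830 nM
compound 2, `C=C1C(=O)[C@]23C[C@@]1(O)CC[C@H]2c1ccc(OS(=O)(=O)c2ccc(C)cc2)c(C)c1[C@@H]3Cn1cc(-c2ccc(C)cc2)nn1`: 1110 nM
compound 3, `C=C1C[C@]23C[C@@]1(O)CC[C@H]2c1ccc(OS(=O)(=O)c2ccc(C)cc2)c(C)c1[C@@H]3Cn1cc(-c2ccc(Cl)cc2)nn1`: > 20000 nM (a limit)

In a functional assay on HL-60 cells (Homo sapiens) for cytotoxicity, read by MTT assay, with a stated time of 4 days (a higher number here means a weaker inhibitor, a lower number a stronger inhibitor), compound 1 gives 830 nM, the lowest of the two numbers shown. Among the compounds with values here, the single one-place step measured, a 1.3-fold higher number from compound 1 to compound 2 (0.13 log units; within the scatter), is (4-methylphenyl)sulfonyl in place of hydrogen on an oxygen on an aromatic ring. For compound 3 this assay reports only a limit (the limit of > 20000 nM in this assay, at which 1 of the 3 values shown sits). Compound 4, `C=C1C(=O)[C@]23C[C@@]1(O)CC[C@H]2c1ccc(O)c(C)c1[C@@H]3Cn1cc(-c2ccccc2)nn1`, differs from compound 1 by hydrogen in place of methyl on an aromatic carbon, read one bond further out as 4-methylphenyl to phenyl. Within the data shown here, no measured step touches this group; the only measured step lies elsewhere and within the scatter, so in this assay no step beyond the scatter is expected. Compound 4 is estimated at 1000 nM, range 400 nM to 2500 nM. The expected step is a 1.2-fold higher number from compound 1 to compound 4 (0.08 log units; within the scatter).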

Compound 4, half-maximal inhibitory concentration: 750 nM
Compound 4: middle estimate off by 1.3-fold (0.12 log units), on the high side; low and high end bracket the measured number.
By their numbers in this assay, from the lowest: compounds 4, 1 and 2 (each within the scatter of the next). At a limit, above all of these: compound 3.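

Taking the methyl off the 4-methylphenyl group gives a 1.1-fold lower number from compound 1 to compound 4 (0.04 log units; within the scatter) in this assay, so this aromatic carbon, para to a large group, carries either hydrogen or methyl with no step beyond the scatter. Within the data shown here, this is the first measured step at this end of the molecule, and it sits within the scatter just as the sulfonyl step on the oxygen does. Nothing shown bears on a reason for this result.

Open, from the compounds shown here alone, is whether a carboxylic acid or an amine on this aromatic carbon would stay within the scatter of compound 4. Compound 3 stands at a limit and differs from these compounds in more than one place, and its chlorine cannot be read alone.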